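Swapping One Group on Compound 1

The source may hold more compounds than are shown below. What is called first, only, known or untested is meant among the compounds shown, and "the series" means these compounds.

Measured in an ADME assay on microsomes from liver (Canis lupus familiaris) for metabolic stability, with a stated time of 10 min; on this read-out lower numbers stand for a less stable compound and higher numbers for a more stable compound:
Compound 1 `FC(F)(F)c1ccccc1-c1ccc2[nH]c(C3=NOC4(CCCCC4)C3)nc2c1`: 71%
Compound 2 `N#Cc1cc(-c2ccccc2C(F)(F)F)cc2nc(C3=NOC4(CCCCC4)C3)[nH]c12`: 51%

Within the data shown here, of these two numbers, the one for compound 1 is the higher, so the next comparison starts from the more stable side of this small set. Compound 3 `CC(C)(O)c1ccccc1-c1ccc2[nH]c(C3=NOC4(CCCCC4)C3)nc2c1` keeps the core of compound 1 and exchanges a single group: 1-hydroxy-1-methylethyl in place of trifluoromethyl on an aromatic carbon. Here 1-hydroxy-1-methylethyl takes the place of trifluoromethyl on an aromatic carbon.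

Among the measured compounds shown here, no measurement yet shows what replacing trifluoromethyl does in this assay. For the measured compounds named here, the only measured step is a number 20 percentage points lower from compound 1 to compound 2 (beyond the scatter). That step is a different exchange, cyano in place of hydrogen, so it bears on this one only loosely, as a guide to how far one change can move the number. On that guide, a modest drop of similar or smaller size is expected, although the direction is far from certain. The estimated step is a number 11 percentage points lower from compound 1 to compound 3 (beyond the scatter). For compound 3 the estimate is 60%, with an expected range from 40% to 80%.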

Compound 3, percent of the compound remaining: 4.4%
The estimate for compound 3 lay 55.6 percentage points above the measured number, outside the stated range (below it).
By their numbers in this assay, from the lowest: compound 3; then compound 2; then compound 1.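

In this assay, putting 1-hydroxy-1-methylethyl in place of trifluoromethyl gives a number 66.6 percentage points lower from compound 1 to compound 3 (beyond the scatter) and makes compound 3 the lowest of the three compounds. This shows that the number is highly sensitive to the group at this place, on an aromatic carbon ortho to a large group, even though the rest of the molecule is unchanged. Size by atom count does not separate the two groups, as each has 4 heavy atoms, no ring and no net charge, whereas the entering group differs in carrying oxygen instead of fluorine, along with 1 hydrogen-bond donor and 1 hydrogen-bond acceptor. Nothing available here explains why the number fell so far.

From the compounds shown here alone, it remains open which part of the new group goes with the low number, the hydroxyl or its carbon frame; a tert-butyl group, which keeps that frame without the hydroxyl, would help to separate the two. Going by these compounds, it is also open how a smaller group such as methoxy, or a carboxylic acid, would fare at this place, and whether the same exchange would have a similar effect on compound 2.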